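A trifluoromethyl-bearing analogue of compound 3

This account rests on a few compounds, and the source may have more. Where it says the series, first, only, none or still open, it means among the compounds named here.

Measured compounds:
compound 1 `O=C(O)c1ccc(F)cc1-c1ccc2c(c1)OC[C@H](Cc1ccccc1)[C@H]2O` — 5 nM; 14 nM; 5 nM (3 entries)
compound 2 `CC(C)c1ccc(C[C@H]2COc3cc(-c4cc(F)ccc4C(=O)O)ccc3[C@@H]2O)cc1` — 210 nM
compound 3 `O=C(O)c1ccc(F)cc1-c1ccc2c(c1)OC[C@H](CCc1ccccc1)[C@H]2O` — 32 nM

In a functional assay with leukotriene B4 receptor (Homo sapiens) as the target (a lower number here means a stronger inhibitor, a higher number a weaker inhibitor), compound 3 gives 32 nM, the lowest of the two single numbers; its nearest neighbour is compound 2 with 210 nM, and compound 1 has several entries, (the several entries of compound 1 in this assay, 5 nM; 14 nM; 5 nM (3 entries)). The change a 6.6-fold lower number from compound 2 to compound 3 (0.82 log units; beyond the scatter) shows what replacing 4-isopropylphenyl with benzyl did.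

Compound 4 `O=C(O)c1ccc(F)cc1-c1ccc2c(c1)OC[C@H](Cc1ccc(C(F)(F)F)cc1)[C@H]2O` differs from compound 3 by 4-(trifluoromethyl)phenyl in place of benzyl on a saturated chain carbon bound to a saturated ring carbon. Compound 1 carries a plain benzyl group at that place, and its values compared with compound 2 suggest that a bulky group added to the ring of that benzyl raised the number. A trifluoromethyl group is smaller than isopropyl, so a lesser shift is expected, and compound 4 is estimated to land near 70 nM, with a likely range from 20 nM to 250 nM. That estimate means a step of a 2.2-fold higher number from compound 3 to compound 4 (0.34 log units; beyond the scatter), expected to stay close to or slightly beyond the scatter.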

Compound 4, half-maximal inhibitory concentration: 1800 nM
The estimate for compound 4 lay 26-fold (1.41 log units) below the measured number; the measured number lies above the stated range.
By their numbers in this assay, from the lowest: compound 3; then compound 2; then compound 4.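

In this assay, placing 4-(trifluoromethyl)phenyl in place of benzyl on a saturated chain carbon bound to a saturated ring carbon gives a 56-fold higher number from compound 3 to compound 4 (1.75 log units; beyond the scatter), so this position is far less forgiving than compound 2 alone suggested. Trifluoromethyl does not behave as a milder stand-in for isopropyl on the aromatic carbon, as the exchange gives an 8.6-fold higher number from compound 2 to compound 4 (0.93 log units; beyond the scatter), which shows that the assay clearly tells these two groups apart. Compound 1, which has neither group on that aromatic ring, gives lower numbers than both compound 2 and compound 4: the several entries of compound 1 in this assay, 5 nM; 14 nM; 5 nM (3 entries)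

Only isopropyl and trifluoromethyl are shown on that ring, so it remains open whether any added group raises the number this far or how much depends on the particular group. A methoxy group or an amine there would help to separate these possibilities, and the reason for the large step remains unknown.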